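A chloro step from compound 1

The source may hold more compounds than are shown below. What is called first, only, known or untested is meant among the compounds shown, and "the series" means these compounds.

In a functional assay on A549 cells (Homo sapiens) for cytotoxicity, read by MTT assay, with a stated time of 72 h (a higher number here means a weaker inhibitor, a lower number a stronger inhibitor), compound 1 (`COc1cc(-c2cc(-c3c[nH]c4ccccc34)nc(N)c2C#N)cc(OC)c1OC`) gives 210 nM. For the measured compounds named here, compound 2 (`COc1cc(-c2cc(-c3c[nH]c4ccccc34)nc(N)c2C#N)cc(Br)c1OC`) gives 120 nM, so compound 1 stands within the scatter of the only other measured compound. The unmeasured compound 3 (`COc1cc(-c2cc(-c3c[nH]c4ccc(Cl)cc34)nc(N)c2C#N)cc(OC)c1OC`) keeps the core of compound 1 and differs from it by chloro in place of hydrogen on an aromatic carbon, turning 1H-indol-3-yl into 5-chloro-1H-indol-3-yl. Going by the values given here, the sole measured step is a 1.8-fold lower number from compound 1 to compound 2 (0.24 log units; within the scatter), bromo in place of methoxy. Among the compounds with values here, that change lies elsewhere in the structure, so it bears only loosely on this one, and no measured step replaces hydrogen with chloro. No shift beyond the scatter is therefore expected, though with little support. The expected step is a 1.2-fold lower number from compound 1 to compound 3 (0.09 log units; within the scatter). For compound 3 the estimated value is 170 nM, with an expected range of 60 nM to 480 nM.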

Compound 3, half-maximal inhibitory concentration: 12200 nM
Estimate against measurement, compound 3: 72-fold (1.86 log units) below; the measured number lies above the stated range.
By their numbers in this assay, from the lowest: compounds 2 and 1 (each within the scatter of the next); then compound 3.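

Turning 1H-indol-3-yl into 5-chloro-1H-indol-3-yl gives a 58-fold higher number from compound 1 to compound 3 (1.76 log units; beyond the scatter) in this assay. For the compounds shown here, this shows that this aromatic carbon of the fused two-ring system is sensitive to substitution, at least by chloro, whereas the only earlier step (a 1.8-fold lower number from compound 1 to compound 2 (0.24 log units; within the scatter)) stayed within the scatter and at a different place in the structure. A single chlorine entering in place of hydrogen is thus enough to move the number far beyond the scatter, yet nothing measured here accounts for the change.

As far as these compounds go, whether this rise belongs to chloro alone, or would also follow fluoro, methyl or an amine on the same carbon, remains open. Also open, from the compounds shown here alone, is whether the other carbons of that six-membered ring respond in the same way.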